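A few compounds are considered here, and "the series" means these few. Any claim that something is new, unique, unknown or untested is made for them only; others in the source may bear on it.

Compound 1 `COC(=O)c1ccc(-c2nn(Cc3ccccc3)c3ccccc23)cc1`: > 10000 nM
Compound 2 `CC(C)OC(=O)c1ccc(-c2nn(Cc3ccccc3)c3ccccc23)cc1`: > 10000 nM

In a functional assay on cells (Platelet, Homo sapiens) for inhibition (on this read-out higher numbers stand for weaker inhibition and lower numbers for stronger inhibition), compound 2 gives > 10000 nM, which is a limit of the assay and not a number. Compound 1 gives > 10000 nM, which is also a limit. The two esters therefore share one boundary: the limit of > 10000 nM in this assay, at which 2 of the 2 values shown sit. For the measured compounds named here, the only measured step, a step that the two limits leave unreadable from compound 1 to compound 2, offers no size to carry forward.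

Compound 3 `CNC(=O)c1ccc(-c2nn(Cc3ccccc3)c3ccccc23)cc1` has methylamino in place of isopropoxy on a carbonyl carbon. Going by the values given here, this change, isopropoxycarbonyl to methylcarbamoyl, has no measured precedent. With only limits to work from, no firm direction can be set, and the most likely outcome is a reading at the same limit. The expected step is a step that the limit leaves unreadable from compound 2 to compound 3, an estimate with little weight. For compound 3 the estimated value is 15000 nM, with an expected range of 4000 nM to 60000 nM.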

Compound 3, half-maximal inhibitory concentration: > 10000 nM
Compound 3: no number, only a limit; the forecaster's own chance of this, stated with the estimate: 70%; the middle value lies beyond the limit too.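

The steps among compound 1, compound 2 and compound 3 cannot be read, as each value is a limit and not a number: the limit of > 10000 nM in this assay, at which 3 of the 3 values shown sit.

The compounds shown leave open how methoxy, isopropoxy and methylamino on the carbonyl carbon rank, and whether any compound in this series gives a readable inhibition value.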